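The compounds below may be only part of what the source reports. "The series", "measured", "known", "first", "only" and "open" are said of these compounds alone.

Of the compounds shown here, two have been measured so far in an assay on CHO cells for displacement of a labelled ligand from prostaglandin D2 receptor 2 (Homo sapiens), read by scintillation counting; a higher number here means a weaker inhibitor, a lower number a stronger inhibitor. Compound 1, `CC(C)c1ccc(S(C)(=O)=O)cc1C#Cc1cc(C#N)ccc1OCC(=O)O`, gives 12 nM. Compound 2, `CN(C)S(=O)(=O)c1cncc(C#Cc2cc(Cl)ccc2OCC(=O)O)c1`, gives 37 nM, the higher of the two numbers, and the gap between them is beyond the scatter. Compound 3, `CS(=O)(=O)c1cncc(C#Cc2cc(Cl)ccc2OCC(=O)O)c1`, differs from compound 2 in one place: methyl in place of dimethylamino on a sulfonyl sulfur, which is methyl in place of dimethylamino on a sulfonyl sulfur. Among the measured compounds shown here, no measured pair shows this change, so the step from compound 2 to compound 3 is expected to be small, most likely within the scatter, with no clear direction. Compound 3 is therefore estimated at 30 nM, with a likely range from 12 nM to 80 nM, meaning an expected step of a 1.2-fold lower number from compound 2 to compound 3 (0.09 log units; within the scatter).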

Compound 3, inhibition constant: 60 nM
Compound 3: middle estimate off by 2.0-fold (0.30 log units), on the low side, within the range that was stated.
By their numbers in this assay, from the lowest: compound 1; then compounds 2 and 3 (each within the scatter of the next).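

In this assay, putting methyl in place of dimethylamino on a sulfonyl sulfur gives a 1.6-fold higher number from compound 2 to compound 3 (0.21 log units; within the scatter) and so does not separate the two compounds. This first one-place comparison shows that, at this place, a group of 1 heavy atom serves as well as one of 3 on the shared core. No measurement shown offers an explanation for this result.

Still open, going by these compounds, is whether a longer chain such as propyl, or an amine such as a plain amino group, on the same sulfur would also leave the number within the scatter.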